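The source may hold more compounds than are shown below. What is called first, only, known or untested is meant among the compounds shown, and "the series" means these compounds.

In an assay on isolated protein for displacement of a labelled ligand from 5-hydroxytryptamine receptor 6 (Homo sapiens) (on this read-out higher numbers stand for weaker inhibition and lower numbers for stronger inhibition), compound 2, `O=S(=O)(c1cccc(F)c1)c1ccc2c(c1)CCC[C@H]2CN1CCCS1(=O)=O`, gives 31.6 nM, the highest of the two numbers in hand. Going by the values given here, its neighbour compound 1, `CN(C[C@@H]1CCCc2cc(S(=O)(=O)c3cccc(F)c3)ccc21)S(N)(=O)=O`, gives 3.98 nM in this assay, and the only measured step between them, a 7.9-fold higher number from compound 1 to compound 2 (0.90 log units; beyond the scatter), shows what the loss of the acyclic sulfamide looked like. Compound 3, `O=C1CN=C(NC[C@@H]2CCCc3cc(S(=O)(=O)c4cccc(F)c4)ccc32)N1`, is the next compound in this assay and differs from compound 2 in one place: a group of 7 heavy atoms (3 carbon, 3 nitrogen, 1 oxygen; one five-membered non-aromatic ring with 2 hetero atoms) in place of a group of 7 heavy atoms (3 carbon, 1 nitrogen, 2 oxygen, 1 sulfur; one five-membered non-aromatic ring with 2 hetero atoms), on a saturated chain carbon bound to a saturated ring carbon. Among the compounds with values here, the one step that bears on this change is the step from compound 1 to compound 2, in which a group with no hydrogen-bond donors replaced one with such donors and the number rose beyond the scatter. The change into compound 3 keeps the five-membered ring but brings back 2 hydrogen-bond donors, so a modest lowering of the number is expected rather than none, though the evidence rests on a single step. Compound 3 is therefore estimated at 15 nM in this assay, within 4 nM to 60 nM, meaning an expected step of a 2.1-fold lower number from compound 2 to compound 3 (0.32 log units; beyond the scatter).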

Compound 3, inhibition constant: 0.1 nM
The estimate for compound 3 lay 150-fold (2.18 log units) above the measured number; measured number outside the range, below it.
By their numbers in this assay, from the lowest: compound 3; then compound 1; then compound 2.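

In this assay, going by these compounds alone, the group on the saturated chain carbon bound to a saturated ring carbon proves far more decisive than the earlier compounds suggested: a 320-fold lower number from compound 2 to compound 3 (2.50 log units; beyond the scatter), although the groups that leave and enter both have 7 heavy atoms and one five-membered non-aromatic ring with 2 hetero atoms. Ring size and heavy-atom count therefore do not settle the number at this position, and the group in compound 3 also surpasses the acyclic sulfamide, with a 40-fold lower number from compound 1 to compound 3 (1.60 log units; beyond the scatter), making compound 3 the strongest of the three in this assay. No measured information accompanies these compounds to account for the size of either step.

The step from compound 2 to compound 3 alters the ring atoms, the carbonyl and the counts of hydrogen-bond donors and acceptors together, so the compounds shown cannot assign the gain to any one of these features. They also leave open whether the ring itself is needed, as an open-chain guanidine or a simple primary amine at the same place has no value here to compare.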